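Sulfonamide-amide series: methyl for fluoro on the amide aryl

This account rests on a few compounds, and the source may have more. Where it says the series, first, only, none or still open, it means among the compounds named here.

Measured compounds:
compound 1, `Cc1ccc(S(=O)(=O)NCc2ccc(CNC(=O)c3ccc(F)cc3)cc2)cc1`: 1 nM
compound 2, `O=C(NCc1ccc(CNS(=O)(=O)c2ccccc2)cc1)c1ccc(F)cc1`: 100 nM
compound 3, `Cc1ccc(S(=O)(=O)NCc2ccc(CNC(=O)c3cccc(F)c3)cc2)cc1`: 1 nM

Among the measured compounds shown here, in an assay on MDA-MB-231 cells for binding affinity to C-X-C chemokine receptor type 4 (Homo sapiens), read by immunofluorescence and microscopy, with stated times of 10 min and 30 min (on this read-out lower numbers stand for an effect already at smaller amounts and higher numbers for an effect only at larger amounts of compound), compound 2 gives the highest of the three numbers; compound 1 and compound 3 both sit far from it, the step of a 100-fold higher number from compound 1 to compound 2 (2.00 log units; beyond the scatter) being the only measured change on the sulfonyl-side ring. For the measured compounds named here, on the carbonyl-side ring the single measured step is no change at the digits printed from compound 1 to compound 3 (within the scatter), which changed nothing at the digits reported.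

Compound 4, `Cc1ccc(C(=O)NCc2ccc(CNS(=O)(=O)c3ccccc3)cc2)cc1`, is compound 2 with a change on the carbonyl-side ring: methyl in place of fluoro on an aromatic carbon. Going by the values given here, no measured step puts methyl in place of fluoro on that ring, so the bearing steps are indirect. The step from compound 1 to compound 2 shows that a methyl on an aromatic ring of this core can matter greatly, while the step from compound 1 to compound 3 shows that moving a fluoro on the carbonyl-side ring did not matter. Taken together, a step lower from compound 2 is expected for compound 4, but its size is uncertain, and a change within the scatter cannot be ruled out.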

Compound 4, effective concentration (reported as EC, without a stated level of effect): 100 nM
The estimate for compound 4 lay 2.5-fold (0.40 log units) below the measured number; low and high end bracket the measured number.
By their numbers in this assay, from the lowest: compounds 1 and 3 (each within the scatter of the next); then compounds 2 and 4 (each within the scatter of the next).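

In this assay, among the compounds shown here, the exchange of 4-fluorophenyl for 4-methylphenyl on the carbonyl gives no change at the digits printed from compound 2 to compound 4 (within the scatter), the first measured change of the group itself at this place, para to a large group, rather than a move of the fluoro. With the sulfonyl-side ring unsubstituted, methyl and fluoro at this position therefore read alike, whereas the methyl on the sulfonyl-side ring accounts for a 100-fold higher number from compound 1 to compound 2 (2.00 log units; beyond the scatter), so a methyl in the shared core does not count equally on both rings. Nothing available explains this difference between the two rings.

As far as these compounds go, whether methyl and fluoro also read alike at this position when the sulfonyl-side ring carries its methyl, as in compound 1, remains open. Also open, from the compounds shown here alone, is how an amine or a carboxylic acid at this position would read on either background.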